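The source may hold more compounds than are shown below. What is called first, only, known or untested is meant among the compounds shown, and "the series" means these compounds.

Series notes. In an assay on LtK cells with ATP-sensitive inward rectifier potassium channel 11 (Homo sapiens) as the target (on this read-out higher numbers stand for an effect only at larger amounts of compound and lower numbers for an effect already at smaller amounts), compound 1 `CCC(=O)Nc1c(C(O)(C(F)(F)F)C(F)(F)F)ccc2ccccc12` gives 15 nM. Compound 2 `O=C(Nc1c(C(O)(C(F)(F)F)C(F)(F)F)ccc2ccccc12)c1ccccc1Cl` gives 2040 nM, and compound 3 `Cc1ccccc1C(=O)Nc1c(C(O)(C(F)(F)F)C(F)(F)F)ccc2ccccc12` gives 5550 nM, the highest of the three numbers; the nearest is compound 2, with a 2.7-fold higher number from compound 2 to compound 3 (0.43 log units; beyond the scatter), and the furthest is compound 1, with a 370-fold higher number from compound 1 to compound 3 (2.57 log units; beyond the scatter). Compound 4 `COc1ccc(C(=O)Nc2c(C(O)(C(F)(F)F)C(F)(F)F)ccc3ccccc23)cc1` differs from compound 3 by 4-methoxyphenyl in place of 2-methylphenyl on a carbonyl carbon. The steps bearing on this are a 140-fold higher number from compound 1 to compound 2 (2.13 log units; beyond the scatter) and a 370-fold higher number from compound 1 to compound 3 (2.57 log units; beyond the scatter), both large and in the same direction, placing each aryl carbonyl far from compound 1, and a 2.7-fold higher number from compound 2 to compound 3 (0.43 log units; beyond the scatter), which is modest. Among the measured compounds shown here, no measured step covers 4-methoxyphenyl itself, so compound 4 is expected to stay within the aryl range, at 4000 nM (range 800 nM to 20000 nM), an expected step of a 1.4-fold lower number from compound 3 to compound 4 (0.14 log units; within the scatter).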

Compound 4, half-maximal effective concentration: 417 nM
Beside the measured number, compound 4's estimate is 9.6-fold (0.98 log units) above it, and the stated range ends above it.
By their numbers in this assay, from the lowest: compound 1; then compound 4; then compound 2; then compound 3.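

On the carbonyl carbon, the aryl groups do not behave as one class: with a 13-fold lower number from compound 3 to compound 4 (1.12 log units; beyond the scatter) and a 4.9-fold lower number from compound 2 to compound 4 (0.69 log units; beyond the scatter), 4-methoxyphenyl stands apart from both 2-methylphenyl and 2-chlorophenyl. Even so, with a 28-fold higher number from compound 1 to compound 4 (1.44 log units; beyond the scatter) still standing, this aryl group closes only part of the gap to ethyl. No evidence at hand accounts for these differences.

Open, from the compounds shown here alone, is whether the methoxy group or its place on the ring carries the change, which 4-methylphenyl or 2-methoxyphenyl could separate. Also open, going by these compounds, is how a longer alkyl chain such as butyl compares with ethyl.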